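The source may hold more compounds than are shown below. What is called first, only, known or untested is meant among the compounds shown, and "the series" means these compounds.

Working notes on the series. Of the compounds shown here, two have been measured in a functional assay on HepG2 cells (Homo sapiens) for cytotoxicity, read by MTT assay, with a stated time of 48 h; on this read-out higher numbers stand for weaker inhibition and lower numbers for stronger inhibition. Compound 1 `CC(C)=CCC/C(C)=C/CC/C(C)=C/CC[C@@H]1[C@@]2(C)CC/C(=N\OCc3cn(-c4ccc(F)c(F)c4F)nn3)C(C)(C)[C@@H]2CC[C@@]1(C)O` gives 37700 nM in this assay. Compound 2 `COc1cccc(-n2cc(COc3ccc(/C=C4\C[C@]5(C)[C@@H](CC/C=C(\C)CC/C=C(\C)CCC=C(C)C)[C@](C)(O)CC[C@H]5C(C)(C)C4=O)cc3)nn2)c1` gives 50100 nM in this assay, and the two numbers lie within the usual scatter of each other, so compound 1 and compound 2 cannot be told apart on this read-out; both sit in a weak range.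

Compound 3 `CC(C)=CCC/C(C)=C/CC/C(C)=C/CC[C@@H]1[C@@]2(C)C/C(=C\c3ccc(OCc4cn(-c5cccc([N+](=O)[O-])c5)nn4)cc3)C(=O)C(C)(C)[C@@H]2CC[C@@]1(C)O` has not yet been measured. It differs from compound 2 in one place: nitro in place of methoxy on an aromatic carbon, meta to a large group, or read one bond further out, 3-methoxyphenyl to 3-nitrophenyl.

Among the measured compounds shown here, no step between measured compounds with this kind of change is available, and the two numbers at hand give no direction. The expectation for this assay is therefore a step from compound 2 to compound 3 of a 1.1-fold lower number from compound 2 to compound 3 (0.05 log units; within the scatter), that is none beyond the scatter. Compound 3 is estimated at 45000 nM in this assay, with a range from 15000 nM to 130000 nM.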

Compound 3, half-maximal inhibitory concentration: 117000 nM
Beside the measured number, compound 3's estimate is 2.6-fold (0.41 log units) below it; the measured number falls inside the stated range.
By their numbers in this assay, from the lowest: compounds 1 and 2 (each within the scatter of the next); then compound 3.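

Among the compounds shown here, replacing 3-methoxyphenyl with 3-nitrophenyl gives a 2.3-fold higher number from compound 2 to compound 3 (0.37 log units; beyond the scatter) in this assay and provides the first single-place comparison. The aromatic carbon meta to a large group therefore does not appear silent on this read-out: with nitro in place of methoxy, the step runs towards weaker inhibition, although its size is only modest and it rests on one pair. No accompanying measurement bears on this step, and the reason for it remains unknown.

Still open, going by these compounds, is whether the step is particular to nitro or would also appear with an amine, a carboxylic acid or a single fluorine atom on the same aromatic carbon, and whether any such group would move the number the other way. A single pair also cannot show whether the same exchange of methoxy for nitro would read the same way on the core of compound 1, so the change cannot yet be treated as general across the series.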